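Estimating Compound 3 From One Measured Step

The compounds below may be only part of what the source reports. "The series", "measured", "known", "first", "only" and "open" are said of these compounds alone.

Values in a functional assay on CCRF-CEM cells (Homo sapiens); on this read-out lower numbers stand for higher toxicity in this test and higher numbers for lower toxicity in this test
- compound 1 `CCOC(=O)NC(=O)NC1=CS(=O)(=O)O[C@@]12[C@@H](CO[Si](C)(C)C(C)(C)C)O[C@@H](n1cc(C)c(=O)n(C)c1=O)[C@@H]2O[Si](C)(C)C(C)(C)C` gives 3000 nM
- compound 2 `C=C(C)C(=O)NC(=O)NC1=CS(=O)(=O)O[C@@]12[C@@H](CO[Si](C)(C)C(C)(C)C)O[C@@H](n1cc(C)c(=O)n(C)c1=O)[C@@H]2O[Si](C)(C)C(C)(C)C` gives 1200 nM

Of these two, compound 2 has the lower number, 1200 nM, and so is the more toxic in this assay. Compound 3 `COC(=O)CC(=O)NC1=CS(=O)(=O)O[C@@]12[C@@H](CO[Si](C)(C)C(C)(C)C)O[C@@H](n1cc(C)c(=O)n(C)c1=O)[C@@H]2O[Si](C)(C)C(C)(C)C` carries (methoxycarbonyl)methyl in place of ((1-methylethenyl)carbonyl)amino on a carbonyl carbon. Among the compounds with values here, only one measured step bears on this: a 2.5-fold lower number from compound 1 to compound 2 (0.40 log units; beyond the scatter), a modest change. It offers weak guidance, since it swapped different groups. A similarly modest rise is expected, with a 2.1-fold higher number from compound 2 to compound 3 (0.32 log units; beyond the scatter) as the estimated step. Compound 3 is estimated at 2500 nM, with an expected range from 800 nM to 7000 nM.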

Compound 3, half-maximal cytotoxic concentration: 29700 nM
The estimate for compound 3 lay 12-fold (1.07 log units) below the measured number; measured number above the stated range.
By their numbers in this assay, from the lowest: compound 2; then compound 1; then compound 3.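

In this assay the group on this carbonyl carbon can move the number much further than the first pair showed: (methoxycarbonyl)methyl gives a 25-fold higher number from compound 2 to compound 3 (1.39 log units; beyond the scatter) and a 9.9-fold higher number from compound 1 to compound 3 (1.00 log units; beyond the scatter) as well. Replacing either ((1-methylethenyl)carbonyl)amino or (ethoxycarbonyl)amino with it thus lowers toxicity in this test. No measurement here accounts for the shift. These compounds cannot separate losing the amino nitrogen from changing the rest of the group. From the compounds shown here alone, how a simple amine or a longer alkyl chain on this carbonyl carbon would read remains open.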